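The source may report more compounds than this note shows. Statements on the series, on what has been measured and on what is new or still open speak of the compounds shown alone.

Measured compounds:
Compound 1 `COc1ccc(-c2nn(-c3ccccc3)cc2CNc2ccc(F)cc2)cc1` — 5980 nM
Compound 2 `COc1ccc(-c2nn(-c3ccccc3)cc2CNc2ccc(C)cc2)cc1` — 8160 nM
Compound 3 `Brc1ccc(NCc2cn(-c3ccccc3)nc2-c2ccc(Br)cc2)cc1` — 5000 nM

In a functional assay on MCF7 cells (Homo sapiens) for antiproliferative activity, read by MTT assay, with a stated time of 48 h (on this read-out lower numbers stand for stronger inhibition and higher numbers for weaker inhibition), compound 2 gives 8160 nM, the highest of the three numbers, yet compound 1 and compound 3 both sit within the scatter of it. Within the data shown here, the only single-point step recorded is a 1.4-fold higher number from compound 1 to compound 2 (0.13 log units; within the scatter), a change of a different kind. Compound 4 `Cc1ccc(NCc2cn(-c3ccccc3)nc2-c2ccc(C)cc2)cc1` differs from compound 2 by methyl in place of methoxy on an aromatic carbon. Among the measured compounds shown here, no measured pair isolates this change; compound 3 carries bromo in place of both methoxy and methyl, and its value stays within the scatter of compound 2. With the three numbers so close, the account expects no step beyond the scatter in this assay, an expected step of a 1.1-fold lower number from compound 2 to compound 4 (0.04 log units; within the scatter). Compound 4 is therefore estimated at 7500 nM, within 3500 nM to 16000 nM.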

Compound 4, half-maximal inhibitory concentration: 7260 nM
For compound 4 the middle estimate is 1.0-fold (0.01 log units) above the measured one; the measured number falls inside the stated range.
By their numbers in this assay, from the lowest: compounds 3, 1, 4 and 2 (each within the scatter of the next).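

Methyl in place of methoxy on this aromatic carbon, para to a large group, gives a 1.1-fold lower number from compound 2 to compound 4 (0.05 log units; within the scatter) in this assay, so this position now has a measured single-point step, which the earlier compounds did not provide. Methoxy can thus leave, and its hydrogen-bond acceptor with it, without the number moving beyond the scatter. Nothing available explains this result. The compounds shown leave open whether an amine or a carboxylic acid at this position would move the number beyond the scatter, and the same question stands for a longer chain.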